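Swapping the aryl group on compound 2

The source may hold more compounds than are shown below. What is called first, only, known or untested is meant among the compounds shown, and "the series" means these compounds.

Measured in an in vitro ADME assay on microsomes from liver (Homo sapiens) for metabolic stability, in the presence of a further agent that is not named here; a higher number here means faster removal of the compound, a lower number slower removal:
Compound 1 `COc1ccc(OC(F)(F)F)cc1Cn1c(C(=O)NCC(C)(C)CO)cc2cc(C#N)ccc21`: 31 mL.min-1.g-1
Compound 2 `COc1ccc(Cl)cc1Cn1c(C(=O)NCC(C)(C)CO)cc2cc(C#N)ccc21`: 10 mL.min-1.g-1
Compound 3 `Cc1ccc(C(F)(F)F)cc1Cn1c(C(=O)NCC(C)(C)CO)cc2cc(C#N)ccc21`: 16 mL.min-1.g-1

Compound 2 gives 10 mL.min-1.g-1 in this assay. Compound 3, at 16 mL.min-1.g-1, lies within the scatter of compound 2, whereas compound 1, at 31 mL.min-1.g-1, lies beyond it.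

The next compound is compound 4 `CCCOc1cccc(Cn2c(C(=O)NCC(C)(C)CO)cc3cc(C#N)ccc32)c1`, which differs from compound 2 in one place: 3-propoxyphenyl in place of 5-chloro-2-methoxyphenyl on a saturated chain carbon bound to an aromatic nitrogen. The 3-propoxyphenyl group enters in place of the 5-chloro-2-methoxyphenyl group.

For the measured compounds named here, only one measured step bears on this change, namely a 3.1-fold lower number from compound 1 to compound 2 (0.49 log units; beyond the scatter), a modest step beyond the scatter. Going by the values given here, it shows that the number can move with a change in this group, but no measured compound carries a 3-propoxyphenyl group, so the guidance is thin. Taking compound 1 at 31 mL.min-1.g-1 as the guide, a modest rise of similar size is expected. The expected step is a 3.0-fold higher number from compound 2 to compound 4 (0.48 log units; beyond the scatter), and this estimate is uncertain. The estimate for compound 4 is 30 mL.min-1.g-1, with an expected range of 12 mL.min-1.g-1 to 70 mL.min-1.g-1.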

Compound 4, intrinsic clearance in microsomes: 10 mL.min-1.g-1
Beside the measured number, compound 4's estimate is 3.0-fold (0.48 log units) above it; the whole stated range lies above it.
By their numbers in this assay, from the lowest: compounds 2, 4, 3 and 1 (each within the scatter of the next, the first and the last beyond it).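

In this assay the exchange of the whole aryl group gives no change at the digits printed from compound 2 to compound 4 (within the scatter) and so leaves the number in place, even though the chlorine is gone and the 5-chloro-2-methoxyphenyl group gives way to 3-propoxyphenyl. For the compounds shown here, the earlier step of a 3.1-fold lower number from compound 1 to compound 2 (0.49 log units; beyond the scatter) showed only that the number can move with a change in this group, whereas this result shows that a much larger exchange on the same saturated chain carbon bound to an aromatic nitrogen need not move it. No measurement shown here accounts for this result.

The compounds shown leave open how much the propoxy chain and the loss of the chlorine each contribute, since the two changes arrive together in compound 4. Also open, on these data alone, is how a butoxy chain, or an amine or a carboxylic acid in place of the propoxy chain, would read in this assay at this position.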